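Swapping chloro for bromo on a sugar ring carbon

This account rests on a few compounds, and the source may have more. Where it says the series, first, only, none or still open, it means among the compounds named here.

Of the compounds shown here, three have been tested in a functional assay on P815 cells (Mus musculus) for antiproliferative activity; on this read-out higher numbers stand for weaker inhibition and lower numbers for stronger inhibition. Compound 1 `Cc1ccc(S(=O)(=O)O[C@@H]2[C@@H](O)[C@H](n3ccc(N)nc3=O)O[C@@H]2CO)cc1` gives only a limit of the assay, > 30 ug/mL. Compound 2 `Nc1nc(=O)n(C2OC(CO)C(Cl)C2O)cc1F` also gives only a limit, > 30 ug/mL. Compound 3 `Nc1ccn(C2OC(CO)C(Cl)C2O)c(=O)n1` sits at a limit as well, > 100 ug/mL. With both ends at limits, a step that the two limits leave unreadable from compound 2 to compound 3 cannot be read. Compound 4 `Nc1ccn(C2OC(CO)C(Br)C2O)c(=O)n1` differs from compound 3 in one place: bromo in place of chloro on a saturated ring carbon. Going by the values given here, no measured step involves this change, and every value so far is a limit, as the limit of > 100 ug/mL in this assay, at which 1 of the 3 values shown sits, and the limit of > 30 ug/mL in this assay, at which 2 of the 3 values shown sit, show, so no shift beyond the scatter can be foreseen in either direction. Compound 4 is estimated at 100 ug/mL, most likely again a limit, within a range from 30 ug/mL to 300 ug/mL. The step of a number no higher from compound 3 to compound 4 (the limit leaves the size open) is expected to be essentially flat.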

Compound 4, concentration for 50% inhibition: > 100 ug/mL
Compound 4 gave a limit, no number; the forecaster's own chance of this, stated with the estimate: 85%; the middle value sits exactly at the limit.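

Compound 3 and compound 4 each give only a limit in this assay, so the step from chloro to bromo cannot be read. The compounds shown leave open whether this swap changes inhibition at all, and how strongly any of them inhibits.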